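The source may hold more compounds than are shown below. What is called first, only, known or untested is meant among the compounds shown, and "the series" means these compounds.

Working notes on the series. In an ADME assay on BJ cells (Homo sapiens) for cytotoxicity, with a stated time of 72 h (a lower number here means that less compound is needed, a higher number that more compound is needed for the effect), compound 1 `COc1ccc(/C=C/[C@@](C)(/C=C/c2ccc(O)cc2)CCC=C(C)C)cc1` returns only a limit of the assay, > 36600 nM. Compound 2 `CC(C)=CCC[C@@](C)(/C=C/c1ccccc1)/C=C/c1ccc(O)cc1` likewise returns only a limit, > 36600 nM. Compound 3 `C=C[C@@](C)(/C=C/c1ccc(Nc2ccccc2)cc1)CCC=C(C)C` also returns only a limit, > 36600 nM. The change from compound 2 to compound 1 is methoxy in place of hydrogen on an aromatic carbon; its step that the two limits leave unreadable from compound 2 to compound 1 cannot be sized because of the limit of > 36600 nM in this assay, at which 3 of the 3 values shown sit. The difference between the cores of compound 3 and compound 2 is not broken down here. Compound 4 `C=C[C@@](C)(/C=C/c1ccc(Nc2ccc(OC)cc2)cc1)CCC=C(C)C` is not yet measured; it differs from compound 3 by methoxy in place of hydrogen on an aromatic carbon, the same change as between compound 2 and compound 1. The step from compound 3 to compound 4 in this assay is expected to be a step that the limit leaves unreadable from compound 3 to compound 4, since all measured values sit at the limit. Compound 4 is therefore estimated at 60000 nM, between 20000 nM and 200000 nM, most probably again only a limit.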

Compound 4, half-maximal effective concentration: > 36600 nM
Compound 4 ended at the assay's limit; the forecaster's own chance of this, stated with the estimate: 85%; the middle value lies beyond the limit too.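

No new step can be read from compound 3 to compound 4 in this assay, since both return only a limit: the limit of > 36600 nM in this assay, at which 4 of the 4 values shown sit. The compounds shown leave open whether methoxy in place of hydrogen on an aromatic carbon changes the read-out at all.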